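Varying the carboxyphenyl ether in allosteric modulators

The source may hold more compounds than are shown below. What is called first, only, known or untested is meant among the compounds shown, and "the series" means these compounds.

Measured compounds:
compound 1, `Cc1c(OCCCCOc2ccc(C(=O)O)cc2F)ccc(C(=O)CC2CCCC2)c1O`: 31.2%
compound 2, `Cc1c(OCCCCOc2ccccc2C(=O)O)ccc(C(=O)CC2CCCC2)c1O`: 32.9%
compound 3, `COc1ccc(C(=O)O)cc1OCCCCOc1ccc(C(=O)CC2CCCC2)c(O)c1C`: 67.6%

In an assay on HEK293 cells for positive allosteric modulation of metabotropic glutamate receptor 3 (Rattus norvegicus), read by thallium flux, with a stated time of 2.5 min (on this read-out higher numbers stand for larger maximal responses and lower numbers for smaller maximal responses), compound 3 stands highest of the three. Its lead is beyond the scatter in both directions, a number 36.4 percentage points higher from compound 1 to compound 3 (beyond the scatter) and a number 34.7 percentage points higher from compound 2 to compound 3 (beyond the scatter), while a number 1.7 percentage points higher from compound 1 to compound 2 (within the scatter) lies within the scatter. Compound 4 `Cc1c(OCCCCOc2ccc(C(=O)O)c(Cl)c2)ccc(C(=O)CC2CCCC2)c1O` differs from compound 3 in one place: 4-carboxy-3-chlorophenyl in place of 5-carboxy-2-methoxyphenyl on an oxygen on a saturated carbon. Going by the values given here, the steps that bear on this are the two large gains on entry of the 5-carboxy-2-methoxyphenyl group; compound 4 gives that group up and instead carries a 4-carboxy-3-chlorophenyl, which resembles the 4-carboxy-2-fluorophenyl of compound 1 more than anything in compound 3. A large downward step is therefore expected, a number 29.6 percentage points lower from compound 3 to compound 4 (beyond the scatter). Compound 4 is estimated at 38%, between 24% and 58%.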

Compound 4, largest response reached (reported as percent of maximum), in percent of the reference or control that the assay uses: 40%
The estimate for compound 4 lay 2 percentage points below the measured number, within the range that was stated.
By their numbers in this assay, from the lowest: compounds 1, 2 and 4 (each within the scatter of the next); then compound 3.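

In this assay, the high response of compound 3 does not carry over to a second substituted carboxyphenyl ether: a number 27.6 percentage points lower from compound 3 to compound 4 (beyond the scatter). The 4-carboxy-3-chlorophenyl group instead places compound 4 level with the other two compounds, with a number 7.1 percentage points higher from compound 2 to compound 4 (within the scatter) and a number 8.8 percentage points higher from compound 1 to compound 4 (within the scatter), so compound 3 alone stands apart among the four. Nothing available accounts for this separation.

From the compounds shown here alone, whether the response of compound 3 rests on the methoxy group or on the placing of the carboxylic acid stays open. Going by these compounds, how an ethoxy group or a tetrazole would fare in this part of the molecule also stays open.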